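Para substituent swap on the shared core: butyl for (trifluoromethyl)sulfanyl

The source may hold more compounds than are shown below. What is called first, only, known or untested is meant among the compounds shown, and "the series" means these compounds.

Measured compounds:
compound 1 `Oc1nc2nonc2nc1Nc1ccc(OC(F)(F)F)cc1Cl`, 1400 nM
compound 2 `Oc1nc2nonc2nc1Nc1ccc(SC(F)(F)F)cc1`, 1400 nM

In an assay on mitochondria from L6 cells (Rattus norvegicus) for activation, with a stated time of 90 min (on this read-out higher numbers stand for an effect only at larger amounts of compound and lower numbers for an effect already at smaller amounts), compound 2 gives 1400 nM, and compound 1 gives 1400 nM; the two stand level at the digits shown, within the scatter. Compound 3 `CCCCc1ccc(Nc2nc3nonc3nc2O)cc1` differs from compound 2 by butyl in place of (trifluoromethyl)sulfanyl on an aromatic carbon. Within the data shown here, no measured pair shows this kind of change, so the direction cannot be read from the data. Compound 3 is expected to stay in the same region, with at most a small loss: a 1.4-fold higher number from compound 2 to compound 3 (0.15 log units; within the scatter). The estimate for compound 3 in this assay is 2000 nM, between 700 nM and 6000 nM.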

Compound 3, half-maximal effective concentration: 2100 nM
Compound 3: the middle estimate sits 1.1-fold (0.02 log units) below what was measured; low and high end bracket the measured number.
By their numbers in this assay, from the lowest: compounds 1, 2 and 3 (each within the scatter of the next).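

In this assay, butyl in place of (trifluoromethyl)sulfanyl on an aromatic carbon gives a 1.5-fold higher number from compound 2 to compound 3 (0.18 log units; within the scatter). This first direct pair shows that, on this read-out, the position accepts a purely carbon chain without a hydrogen-bond acceptor in place of the sulfur- and fluorine-bearing group. No available data bear on the reason for this result.

As far as these compounds go, whether an amine, a carboxylic acid or a longer chain at this position would stay at the same level remains open. From the compounds shown here alone, whether the same swap behaves alike on other read-outs also remains open.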